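Trifluoromethyl in Place of Nitro on a Cyanoaziridine Urea

This account rests on a few compounds, and the source may have more. Where it says the series, first, only, none or still open, it means among the compounds named here.

The study measured three compounds on a shared cyanoaziridine core. Compound 1 `N#CC1CN1C(=O)Nc1ccc(Cl)c(Cl)c1` gives 7200 nM in a functional assay on MCF7 cells (Homo sapiens) for inhibition; on this read-out lower numbers stand for stronger inhibition and higher numbers for weaker inhibition. Compound 2 `N#CC1CN1C(=O)Nc1ccc([N+](=O)[O-])cc1` gives 3000 nM in this assay, the lower of the two numbers recorded, and the gap up to compound 1 lies beyond the usual scatter of this assay. Compound 3 `N#CC1CN1C(N)=O`, which carries no aryl group at all, shows > 54000 nM in this assay, and this is a limit of the assay rather than a number (the limit of > 54000 nM in this assay, at which 1 of the 3 values shown sits).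

Compound 4 `N#CC1CN1C(=O)Nc1ccc(C(F)(F)F)cc1` has not yet been measured. It differs from compound 2 in one place: trifluoromethyl in place of nitro on an aromatic carbon. Among the compounds with values here, no pair among the measured compounds differs in a single place, so there is no measured step to lean on. The step from compound 2 to compound 4 is expected to be a moderate rise, a 1.7-fold higher number from compound 2 to compound 4 (0.22 log units; within the scatter), that is, a somewhat weaker inhibition. Compound 4 is therefore estimated at 5000 nM in this assay, with a range from 1500 nM to 16000 nM.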

Compound 4, half-maximal inhibitory concentration: 1400 nM
Beside the measured number, compound 4's estimate is 3.6-fold (0.55 log units) above it, outside the stated range (below it).
By their numbers in this assay, from the lowest: compound 4; then compound 2; then compound 1. At a limit, above all of these: compound 3.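

In this assay, trifluoromethyl in place of nitro on an aromatic carbon gives a 2.1-fold lower number from compound 2 to compound 4 (0.33 log units; beyond the scatter), the only single-place step among the compounds shown, so this position is now seen to respond to a change of group. The nitro does not have to stay for the number to remain low, since the group that enters in compound 4 has no hydrogen-bond acceptors and still gives the lowest number of the set. Nothing among the data shown accounts for why this step goes in this direction.

What the compounds shown leave open is whether an amine, a carboxylic acid, a methoxy group or a longer chain on the same aromatic carbon would follow or break this step. On these data alone, with one step at one position, it also stays open whether trifluoromethyl would give a lower number on another aromatic carbon of the ring.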